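A few compounds are considered here, and "the series" means these few. Any claim that something is new, unique, unknown or untested is made for them only; others in the source may bear on it.

Among the measured compounds shown here, in a physicochemical assay for solubility, read by HPLC, using the shake flask method, measured as kinetic solubility, with a stated time of 20 h, at pH 6.5, tested at 200 uM (a higher number here means a more soluble compound, a lower number a less soluble compound), compound 1 (`CS(=O)(=O)Nc1ccc2nccc(-c3ccncc3)c2n1`) gives 90000 nM as the only true number so far. Compound 3 (`Nc1cccc(-c2ccc3nccc(-c4ccncc4)c3n2)c1`) keeps the core of compound 1 but carries 3-aminophenyl in place of methanesulfonamido on an aromatic carbon, next to the ring nitrogen (3-aminophenyl in place of methanesulfonamido on an aromatic carbon). For the measured compounds named here, compound 2 (`O=S(=O)(NCCO)c1cccc(-c2ccc3nccc(-c4ccc(OC(F)(F)F)cc4)c3n2)c1`) also bears an aromatic ring of carbon only at that place, and its result of < 5000 nM is a limit of the assay and not a number, yet this is the one guide available and it suggests that compound 3 will dissolve less well than compound 1. Going by the values given here, no measured pair isolates this change. The expected step is a 6.0-fold lower number from compound 1 to compound 3 (0.78 log units; beyond the scatter) in this assay and so lies beyond the usual scatter. For compound 3 the estimated solubility is 15000 nM with an expected range from 5000 nM to 60000 nM in this measurement.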

Compound 3, solubility: < 5000 nM
Compound 3: only a limit was reported (the forecaster's own chance of this, stated with the estimate: 25%); middle value at least 3.0-fold (0.47 log units) from the limit.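

On the core of compound 1, at this aromatic carbon next to the ring nitrogen, replacing methanesulfonamido with 3-aminophenyl now has a direct reading in this assay: the change gives an at least 18-fold lower number from compound 1 to compound 3 (1.25 log units; beyond the scatter). The result for compound 3 is a limit of the assay and not a number, so the step has an open end. Compound 2 and compound 3 both carry an aromatic ring of carbon only at this place, and neither gives a true number: the limit of < 5000 nM in this assay, at which 2 of the 3 values shown sit.

From the compounds shown here alone, how much of the step comes from losing methanesulfonamido and how much from gaining the aromatic ring remains open, as does the true value of compound 3. Also open, going by these compounds, is how a plain amine at this place, or a carboxylic acid in place of the amino group on the ring, would read in this assay.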